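The compounds below may be only part of what the source reports. "The series", "measured", "known", "first", "only" and "open" are said of these compounds alone.

Measured compounds:
- compound 1, `COc1cc(/C=C/C(=O)C2=C(/C=C/c3ccc(O)c(OC)c3)NC(=O)NC2c2ccccc2)ccc1O`: 38.2%
- compound 2, `COc1cc(/C=C/C(=O)C2=C(/C=C/c3ccc(O)c(OC)c3)NC(=O)NC2c2ccc(C)cc2)ccc1O`: 38.2%
- compound 3, `COc1cc(/C=C/C(=O)C2=C(/C=C/c3ccc(O)c(OC)c3)NC(=O)NC2c2cccc([N+](=O)[O-])c2)ccc1O`: 66.3%

In a functional assay, with a stated time of 20 min, tested at 20 uM (on this read-out higher numbers stand for a stronger effect at the one concentration tested and lower numbers for a weaker effect), compound 3 gives the highest of the three numbers; the nearest and the furthest, compound 1 and compound 2, both sit lower by a number 28.1 percentage points higher from compound 1 to compound 3 (beyond the scatter) and a number 28.1 percentage points higher from compound 2 to compound 3 (beyond the scatter). Compound 1 and compound 2 are within the scatter of each other, no change at the digits printed from compound 1 to compound 2 (within the scatter).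

Compound 4, `COc1cc(/C=C/C(=O)C2=C(/C=C/c3ccc(O)c(OC)c3)NC(=O)NC2c2ccccc2Cl)ccc1O`, is the next candidate. The change from compound 3 is 2-chlorophenyl in place of 3-nitrophenyl on a saturated ring carbon. Among the measured compounds shown here, two steps bear on it: a number 28.1 percentage points higher from compound 1 to compound 3 (beyond the scatter) and a number 28.1 percentage points higher from compound 2 to compound 3 (beyond the scatter) both show that the 3-nitrophenyl sits higher than a phenyl or 4-methylphenyl on that ring carbon. For the measured compounds named here, compound 4 carries none of these groups; no measured step holds a 2-chlorophenyl, so what a chlorine on that ring does is unknown here. Given that the rise rested on the nitro group, a fall back toward the level of compound 1 is expected, a number 24.3 percentage points lower from compound 3 to compound 4 (beyond the scatter). Compound 4 is therefore estimated at 42% in this assay, between 25% and 62%.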

Compound 4, a percentage reported as activity, at one concentration (the size of the read-out at that concentration, not a potency): 46%
Beside the measured number, compound 4's estimate is 4 percentage points below it; the range from low to high includes it.
By their numbers in this assay, from the lowest: compounds 1, 2 and 4 (each within the scatter of the next); then compound 3.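

In this assay, replacing the 3-nitrophenyl on the saturated ring carbon with a 2-chlorophenyl does not keep the higher level of compound 3: a number 20.3 percentage points lower from compound 3 to compound 4 (beyond the scatter). Against the unsubstituted phenyl and the 4-methylphenyl, the 2-chlorophenyl stays within the scatter, with a number 7.8 percentage points higher from compound 1 to compound 4 (within the scatter) and a number 7.8 percentage points higher from compound 2 to compound 4 (within the scatter), so among the four compounds only compound 3 stands apart, and a chloro group at this place shows no separable step, as with the methyl group in compound 2. No measured property of these compounds bears on this result.

Compound 3 and compound 4 differ in both the group on the aromatic ring and its place on that ring, and the compounds shown do not separate these two changes. As far as these compounds go, whether the higher level is tied to nitro itself stays open, and a nitrile or a carboxylic acid on that ring would test it.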